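Swapping Isobutyl for (Pyridin-3-yl)methyl in a Boronic Acid

The source may hold more compounds than are shown below. What is called first, only, known or untested is meant among the compounds shown, and "the series" means these compounds.

In a functional assay on B16 cells (Mus musculus) for inhibition (a lower number here means a stronger inhibitor, a higher number a weaker inhibitor), compound 1 `CC(C)CN(CC(=O)N(CC(C)C)NC(=O)OCc1ccccc1)NC(=O)CBr` gives 1300 nM, while compound 2 `CC(C)CN(CC(=O)N(CC(C)C)NC(=O)OCc1ccccc1)/N=C/c1cccc(B(O)O)c1` gives 53900 nM, the higher of the two numbers. Compound 3 `CC(C)CN(CC(=O)N(Cc1cccnc1)NC(=O)OCc1ccccc1)/N=C/c1cccc(B(O)O)c1` brings a further change: pyridin-3-yl in place of isopropyl on a saturated chain carbon bound to an amide-type nitrogen, so that isobutyl becomes (pyridin-3-yl)methyl. Among the compounds with values here, the only measured step, a 41-fold higher number from compound 1 to compound 2 (1.62 log units; beyond the scatter), was large, but it changed an amine nitrogen and not this carbon, so it gives no direct guide. In this assay the expected change is small, within the scatter and slightly downward, as a 1.5-fold lower number from compound 2 to compound 3 (0.19 log units; within the scatter). For compound 3 the estimated value is 35000 nM, with an expected range of 10000 nM to 100000 nM.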

Compound 3, half-maximal inhibitory concentration: 21100 nM
Beside the measured number, compound 3's estimate is 1.7-fold (0.22 log units) above it; the range from low to high includes it.
By their numbers in this assay, from the lowest: compound 1; then compound 3; then compound 2.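

Pyridin-3-yl in place of isopropyl on a saturated chain carbon bound to an amide-type nitrogen gives a 2.6-fold lower number from compound 2 to compound 3 (0.41 log units; beyond the scatter) in this assay and is the first change read at this position. The step is modest but beyond the scatter, so this carbon does respond, and isobutyl is not required there for the number to fall. Nothing measured here explains the difference. A benzyl group at this carbon would separate the effect of the ring from that of its nitrogen. Also open, on these data alone, is whether the swap would act alike on the bromoacetamide compound 1.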